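A few compounds are considered here, and "the series" means these few. Any claim that something is new, unique, unknown or untested is made for them only; others in the source may bear on it.

In a functional assay on MCF7 cells (Homo sapiens) for antiproliferative activity, read by sulforhodamine B assay, with a stated time of 72 h (a higher number here means a weaker inhibitor, a lower number a stronger inhibitor), compound 1 `Cc1ccc(S(=O)(=O)Nc2cc(SCC(=O)N[C@@H](CC(C)C)B(O)O)c(O)c3ccccc23)cc1` gives 12800 nM and compound 2 `Cc1ccc(S(=O)(=O)Nc2cc(SCCC(=O)N[C@@H](CC(C)C)B(O)O)c(O)c3ccccc23)cc1` gives 6940 nM. Within the data shown here, the only measured step, a 1.8-fold lower number from compound 1 to compound 2 (0.27 log units; within the scatter), lies within the scatter, so these numbers do not separate the two compounds. Compound 3 `CC(C)C[C@H](NC(=O)CCSc1cc(NS(=O)(=O)c2ccccc2)c2ccccc2c1O)B(O)O` keeps the chain of compound 2 and carries a different change: hydrogen in place of methyl on an aromatic carbon, para to a large group, which turns 4-methylphenyl into phenyl (hydrogen in place of methyl on an aromatic carbon). Among the measured compounds shown here, the measured step concerns the chain on the sulfur, and no measured pair tests this methyl. The starting point for an expectation is therefore compound 2 at 6940 nM, with no shift beyond the scatter expected in this assay. The expected change is a 1.0-fold higher number from compound 2 to compound 3 (0.00 log units; within the scatter). For compound 3 the estimated value is 7000 nM, with an expected range from 3000 nM to 16000 nM.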

Compound 3, half-maximal inhibitory concentration: 7460 nM
For compound 3 the middle estimate is 1.1-fold (0.03 log units) below the measured one, within the range that was stated.
By their numbers in this assay, from the lowest: compounds 2, 3 and 1 (each within the scatter of the next).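

Hydrogen in place of methyl on the aromatic carbon para to a large group, which turns 4-methylphenyl into phenyl, gives a 1.1-fold higher number from compound 2 to compound 3 (0.03 log units; within the scatter) in this assay and so does not separate the two compounds. Compounds 1 and 2 both carry this methyl and differ only in the chain on the sulfur, so they could say nothing about it. Compound 3 shows that, with the chain of compound 2, activity in this assay does not depend measurably on the methyl, and no evidence at hand bears on the reason for this result.

As far as these compounds go, whether a larger or different group at this place, such as methoxy, a chlorine atom or a carboxylic acid, would shift the number remains open. So does whether phenyl behaves the same way with the shorter chain of compound 1.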